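The source may hold more compounds than are shown below. What is called first, only, known or untested is meant among the compounds shown, and "the series" means these compounds.

Compound 2 `Cc1cc2cc(NS(=O)(=O)Cc3ccc(C(=O)NO)cc3)ccc2n(C)c1=O` and compound 1 `COC(=O)c1ccc(CS(=O)(=O)Nc2ccc3c(c2)cc(C)c(=O)n3C)cc1` share one core and differ by methoxy in place of hydroxyamino on a carbonyl carbon. In a functional assay on THP-1 cells (Homo sapiens) for antiproliferative activity, tested at 20 uM (on this read-out lower numbers stand for a weaker effect and higher numbers for a stronger effect at the one concentration tested), compound 2 gives 8% and compound 1 gives 9%, a step of a number 1 percentage points higher from compound 2 to compound 1 (within the scatter). Compound 3 `COc1ccc(C(=O)NO)cc1S(=O)(=O)Nc1ccc2c(c1)cc(C)c(=O)n2C` rests on a different core, and the difference between the two cores is not broken down here. In this assay compound 3 gives 32%, the highest of the three numbers. Among the compounds with values here, compound 4 `COC(=O)c1ccc(OC)c(S(=O)(=O)Nc2ccc3c(c2)cc(C)c(=O)n3C)c1` is related to compound 3 by methoxy in place of hydroxyamino on a carbonyl carbon, the same change as the one made from compound 2 to compound 1, at the same kind of place. Because the earlier step was a number 1 percentage points higher from compound 2 to compound 1 (within the scatter), the step from compound 3 to compound 4 is expected to be a number 1 percentage points lower from compound 3 to compound 4 (within the scatter). Compound 4 is estimated to give 31%, between 16% and 46%, in this assay.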

Compound 4, a percentage reported as inhibition, at one concentration (the size of the read-out at that concentration, not a potency): 101%
Compound 4: the middle estimate sits 70 percentage points below what was measured; measured number outside the range, above it.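

On the core of compound 3, methoxy in place of hydroxyamino on a carbonyl carbon gives a step of a number 69 percentage points higher from compound 3 to compound 4 (beyond the scatter) in this assay. The size of this step did not carry over from one core to the other: the same change on two cores in this assay, a number 1 percentage points higher (within the scatter) from compound 2 to compound 1 and a number 69 percentage points higher (beyond the scatter) from compound 3 to compound 4, 68 percentage points apart, beyond the scatter of two such steps

This shows that the outcome of the change depends on the core in these two pairs, but two pairs do not show which part of the cores matters or how the change would behave on a third core.

The compounds shown leave open how a carboxylic acid or an ethoxy group on the same carbonyl carbon would read on either core. They also leave open how these compounds would compare at other concentrations.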